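The source may hold more compounds than are shown below. What is called first, only, known or untested is meant among the compounds shown, and "the series" means these compounds.

Compound 2 `OC[C@H]1O[C@@H](n2cnc3c(NCc4ccc(Br)cc4)ncnc32)[C@H](O)[C@@H]1O` gives 47400 nM in a functional assay on HL-60 cells (Homo sapiens) for antiproliferative activity, with a stated time of 72 h (a higher number here means a weaker inhibitor, a lower number a stronger inhibitor), the highest of the three numbers recorded; compound 3 `COc1ccc(CNc2ncnc3c2ncn3[C@@H]2O[C@H](CO)[C@@H](O)[C@H]2O)c(OC)c1` stands within the scatter of it at 39000 nM, whereas compound 1 `OC[C@H]1O[C@@H](n2cnc3c(NCc4ccc(F)cc4)ncnc32)[C@H](O)[C@@H]1O` lies far lower at 1200 nM. Both steps away from compound 1 are large: a 40-fold higher number from compound 1 to compound 2 (1.60 log units; beyond the scatter) and a 33-fold higher number from compound 1 to compound 3 (1.51 log units; beyond the scatter). Compound 4 `COc1cc(CNc2ncnc3c2ncn3[C@@H]2O[C@H](CO)[C@@H](O)[C@H]2O)cc(OC)c1` is reached from compound 2 by 3,5-dimethoxyphenyl in place of 4-bromophenyl on a saturated chain carbon bound to a nitrogen on an aromatic ring. The step that bears most directly on this change is a 1.2-fold lower number from compound 2 to compound 3 (0.08 log units; within the scatter), where a dimethoxyphenyl already took the place of the 4-bromophenyl without any shift beyond the scatter. Going by the values given here, no measured compound carries the 3,5-dimethoxyphenyl, so the two dimethoxy arrangements can only be treated as alike on the evidence at hand. The expected step is therefore a 1.2-fold lower number from compound 2 to compound 4 (0.07 log units; within the scatter), that is, nothing beyond the scatter, with compound 3 as the anchor. Compound 4 is accordingly estimated at 40000 nM, with a range from 12000 nM to 130000 nM.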

Compound 4, half-maximal inhibitory concentration: 20200 nM
The estimate for compound 4 lay 2.0-fold (0.30 log units) above the measured number; measured number inside the range.
By their numbers in this assay, from the lowest: compound 1; then compounds 4, 3 and 2 (each within the scatter of the next, the first and the last beyond it).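

In this assay, going by these compounds alone, the 3,5-dimethoxyphenyl is the first dimethoxyphenyl at this position to stand apart from the 4-bromophenyl beyond the scatter, though only modestly (a 2.3-fold lower number from compound 2 to compound 4 (0.37 log units; beyond the scatter)), while the two dimethoxy arrangements remain within the scatter of each other (a 1.9-fold lower number from compound 3 to compound 4 (0.29 log units; within the scatter)). The change of arrangement therefore does not bring either dimethoxy compound near the 4-fluorophenyl of compound 1, which stays far apart (a 17-fold higher number from compound 1 to compound 4 (1.23 log units; beyond the scatter)). No measurement offered here accounts for these differences.

The compounds shown leave open whether the low number of compound 1 is particular to the 4-fluorophenyl, or whether a 4-chlorophenyl, a 3-fluorophenyl or an unsubstituted phenyl on the same saturated chain carbon would give a similar number. They also leave open how a single methoxy group on the phenyl would compare with the two dimethoxy arrangements.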